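Pentacyclic series: cyclopropylamino for chloro, tolerability outlook

A few compounds are considered here, and "the series" means these few. Any claim that something is new, unique, unknown or untested is made for them only; others in the source may bear on it.

Three compounds of this series have been run in an ADME assay on Vero cells (Chlorocebus sabaeus) for cytotoxicity (a lower number here means that less compound is tolerated, a higher number that more compound is tolerated), and none of them has returned a number. Compound 1 `COCCNc1ccn2nc(-c3ccc(F)cc3)c(-c3ccnc(NC4CCCC4)n3)c2c1` gives > 40000 nM in this assay, which is a limit of the measurement rather than a value. Compound 2 `CN(C)c1cc(Cl)cc2c(-c3ccnc(NC4CCCC4)n3)c(-c3ccc(F)cc3)nn12` likewise gives > 40000 nM, again a limit. Compound 3 `COc1ccc(-c2nn3c(Cl)cc(Cl)cc3c2-c2ccnc(NC3CCCC3)n2)cc1` also gives > 40000 nM, a limit and not a number. Where compound 3 stands can therefore only be stated as a floor: it sits at the limit of > 40000 nM in this assay, at which 3 of the 3 values shown sit, together with every other compound measured so far, so no ordering among compounds 1, 2 and 3 can be drawn from these data.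

Compound 4 `COc1ccc(-c2nn3c(NC4CC4)cc(Cl)cc3c2-c2ccnc(NC3CCCC3)n2)cc1` has not yet been measured. It differs from compound 3 by cyclopropylamino in place of chloro on an aromatic carbon. Going by the values given here, no measured pair shows the effect of such a change, and nothing in the present data points either way. Among the compounds with values here, the step from compound 3 to compound 4 is expected to be a number no higher from compound 3 to compound 4 (the limit leaves the size open), that is, no shift beyond the usual scatter, since every compound so far sits at the limit of > 40000 nM in this assay, at which 3 of the 3 values shown sit. For compound 4 the estimate in this assay is 40000 nM, within a range from 12000 nM to 100000 nM, with a substantial chance that only a limit is again reported.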

Compound 4, half-maximal cytotoxic concentration: > 40000 nM
Compound 4: no number, only a limit (the forecaster's own chance of this, stated with the estimate: 70%); the middle value lies on the limit itself.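

In this assay compound 4 gives > 40000 nM, a limit and not a number. Compound 3 also sits at a limit, so no step between compound 3 and compound 4 can be read: the limit of > 40000 nM in this assay, at which 4 of the 4 values shown sit.

The compounds shown leave open whether cyclopropylamino in place of chloro on an aromatic carbon shifts the read-out in this assay at all.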